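The source may hold more compounds than are shown below. What is called first, only, known or untested is meant among the compounds shown, and "the series" means these compounds.

In a functional assay on SW480 cells (Homo sapiens) for inhibition, read by luminescence and resazurin assay, with a stated time of 3 days (on this read-out higher numbers stand for weaker inhibition and lower numbers for stronger inhibition), compound 1 `CCCNc1nc(NCc2ccc(C(=O)Nc3ccc(F)cc3)cc2)c2ccccc2n1` gives 1600 nM. Compound 2 `CN(C)CCCNc1nc(NCc2ccc(NC(=O)c3ccc(CN4CCN(C)CC4)cc3)cc2)c2ccccc2n1` reaches the limit of > 20000 nM in this assay, so no number is known for it. Compound 3 `CC1CN(c2nc(NCc3ccc(C(=O)Nc4ccc(F)cc4)cc3)c3ccccc3n2)CCN1` gives 3200 nM; among the two numbers shown it is the higher, yet the step of a 2.0-fold higher number from compound 1 to compound 3 (0.30 log units; within the scatter) stays within the scatter. Compound 4 `CCNc1nc(NCc2ccc(C(=O)Nc3ccc(F)cc3)cc2)c2ccccc2n1` differs from compound 3 by ethylamino in place of 3-methylpiperazin-1-yl on an aromatic carbon. Among the measured compounds shown here, the one measured step that bears on this change is a 2.0-fold higher number from compound 1 to compound 3 (0.30 log units; within the scatter), in which the same ring entered in place of propylamino and the number hardly moved; putting ethylamino back should likewise move it little. Compound 4 is therefore expected to give about 1800 nM, between 700 nM and 4500 nM. The expected step of a 1.8-fold lower number from compound 3 to compound 4 (0.25 log units; within the scatter) stays within the scatter.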

Compound 4, half-maximal inhibitory concentration: 2500 nM
The estimate for compound 4 lay 1.4-fold (0.14 log units) below the measured number, and the stated range covers the measured number.
By their numbers in this assay, from the lowest: compounds 1, 4 and 3 (each within the scatter of the next). At a limit, above all of these: compound 2.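

The step of a 1.3-fold lower number from compound 3 to compound 4 (0.11 log units; within the scatter) shows that, at this position between two ring nitrogen atoms, an open ethylamino chain and the 3-methylpiperazin-1-yl ring give numbers that cannot be told apart. Chain length makes no clear difference either, as the step of a 1.6-fold higher number from compound 1 to compound 4 (0.19 log units; within the scatter) is also small. Nothing measured here bears on why these steps are small. Still open, going by these compounds, is whether a much longer chain, a plain amino group or a carboxylic acid at this position would move the number beyond the scatter.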